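This account rests on a few compounds, and the source may have more. Where it says the series, first, only, none or still open, it means among the compounds named here.

Of the compounds shown here, two have been measured so far. Compound 1, `O=C(/C=C/c1ccc(Cl)cc1)Nc1cc(-c2ccc(Br)cc2)[nH]n1`, gives 1080 nM in a functional assay on B16-F10 cells (Mus musculus) for antiproliferative activity, read by MTT assay, with a stated time of 48 h; a higher number here means a weaker inhibitor, a lower number a stronger inhibitor. Compound 2, `O=C(/C=C\c1ccc(C(F)(F)F)cc1)Nc1cc(-c2ccccc2)[nH]n1`, gives 640 nM in this assay. These two values sit within the scatter of each other, so neither compound can be called the stronger inhibitor on this evidence. Compound 3, `COc1ccc(/C=C\C(=O)Nc2cc(-c3ccccc3)[nH]n2)cc1`, has not yet been measured. It differs from compound 2 in one place: methoxy in place of trifluoromethyl on an aromatic carbon. No measured pair in this set shows the effect of exchanging these two groups, and the data give no reason to expect a move in either direction beyond the usual scatter. The step that is expected is therefore a 1.1-fold higher number from compound 2 to compound 3 (0.04 log units; within the scatter), a step of no more than the usual scatter. Compound 3 is expected to give about 700 nM in this assay, with a plausible range from 250 nM to 2000 nM.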

Compound 3, half-maximal inhibitory concentration: 950 nM
The estimate for compound 3 lay 1.4-fold (0.13 log units) below the measured number, and the stated range covers the measured number.
By their numbers in this assay, from the lowest: compounds 2, 3 and 1 (each within the scatter of the next).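

Within the data shown here, this is the first pair in the set that differs in one place, so it gives the first direct reading of this position, an aromatic carbon para to a large group. In this assay, putting methoxy in place of trifluoromethyl gives a 1.5-fold higher number from compound 2 to compound 3 (0.17 log units; within the scatter), so compound 2 and compound 3 cannot be told apart, even though methoxy has 2 heavy atoms and 1 hydrogen-bond acceptor, while trifluoromethyl has 4 heavy atoms and 0 hydrogen-bond acceptors. No measurement is available that would explain this result.

As far as these compounds go, whether an amine or a carboxylic acid on this same carbon would also stay within the scatter of compound 2 remains open. A single pair also leaves open whether the same exchange would give a similar step in compounds with other changes elsewhere.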